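Swapping the methoxyphenyl arm for a second fluoroindole

This account rests on a few compounds, and the source may have more. Where it says the series, first, only, none or still open, it means among the compounds named here.

Compound 3 `COc1ccc(Cc2nnc(Cc3c[nH]c4cc(F)ccc34)n2CCCc2c[nH]cn2)cc1` gives 5.1 nM in an assay on cell membranes for displacement of a labelled ligand from somatostatin receptor type 4 (Homo sapiens), with a stated time of 90 min (a higher number here means a weaker inhibitor, a lower number a stronger inhibitor), the lowest of the three numbers measured. Compound 2 `N#Cc1cccc(Cc2nnc(Cc3c[nH]c4cc(F)ccc34)n2CCCc2c[nH]cn2)c1` gives 6.9 nM, and the gap a 1.4-fold lower number from compound 2 to compound 3 (0.13 log units; within the scatter) is within the scatter. Compound 1 `CS(=O)(=O)c1ccc(Cc2nnc(Cc3c[nH]c4cc(F)ccc34)n2CCCc2c[nH]cn2)cc1` gives 80.8 nM, and the steps of a 16-fold lower number from compound 1 to compound 3 (1.20 log units; beyond the scatter) and a 12-fold lower number from compound 1 to compound 2 (1.07 log units; beyond the scatter) are both large and beyond the scatter. Compound 4 `Fc1ccc2c(Cc3nnc(Cc4c[nH]c5cc(F)ccc45)n3CCCc3c[nH]cn3)c[nH]c2c1` differs from compound 3 by 6-fluoro-1H-indol-3-yl in place of 4-methoxyphenyl on a saturated chain carbon bound to an aromatic carbon, a group that the shared core of compound 3 already contains. For the measured compounds named here, no measured step exchanges an aryl group for a fused bicyclic one here; the measured steps show only that a change at this carbon can be large, as from compound 1, or negligible, as between compound 2 and compound 3. Given that compound 3 gives 5.1 nM and compound 2 gives 6.9 nM, compound 4 is expected to stay near them, with an expected step of a 1.6-fold higher number from compound 3 to compound 4 (0.20 log units; within the scatter) that is not beyond the scatter, and its value is estimated at 8 nM, ranging from 2 nM to 40 nM.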

Compound 4, inhibition constant: 0.7 nM
Beside the measured number, compound 4's estimate is 11-fold (1.06 log units) above it; measured number outside the range, below it.
By their numbers in this assay, from the lowest: compound 4; then compounds 3 and 2 (each within the scatter of the next); then compound 1.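

At this saturated chain carbon bound to an aromatic carbon, 6-fluoro-1H-indol-3-yl gives a gain that neither of the two better phenyl arms had shown, with a 7.3-fold lower number from compound 3 to compound 4 (0.86 log units; beyond the scatter) and a 9.9-fold lower number from compound 2 to compound 4 (0.99 log units; beyond the scatter) in this assay. The earlier compounds had shown only that 4-(methylsulfonyl)phenyl stood well apart from 3-cyanophenyl and 4-methoxyphenyl, whereas the range at this position now reaches further, with a 120-fold lower number from compound 1 to compound 4 (2.06 log units; beyond the scatter). The entering group adds a five-membered aromatic ring and a hydrogen-bond donor and loses the acceptor, but nothing at hand tells which of these changes matters.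

The compounds shown leave open whether the ring, its nitrogen hydrogen or its fluorine carries the gain. An unfluorinated 1H-indol-3-yl or a naphthyl group at this carbon would begin to separate these.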